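From phenyl to 3-carboxyphenyl: an estimate for compound 3

A few compounds are considered here, and "the series" means these few. Any claim that something is new, unique, unknown or untested is made for them only; others in the source may bear on it.

Measured in a functional assay on L1210 cells (Mus musculus); a higher number here means a weaker inhibitor, a lower number a stronger inhibitor:
- Compound 1 `Cc1ccc2nc(N)nc(O)c2c1Sc1ccc(C(=O)N[C@H](C(=O)O)c2ccccc2)cc1`: 2000 nM
- Compound 2 `Cc1ccc2nc(N)nc(O)c2c1Sc1ccc(C(=O)N[C@H](C(=O)O)c2cccc(O)c2)cc1`: 700 nM

Not yet measured:
- Compound 3 `Cc1ccc2nc(N)nc(O)c2c1Sc1ccc(C(=O)N[C@H](C(=O)O)c2cccc(C(=O)O)c2)cc1`

Compound 1, at 2000 nM, has the higher of the two numbers, which makes it the weaker inhibitor of the pair. Compound 3 differs from it by carboxy in place of hydrogen on an aromatic carbon, meta to a large group, so phenyl becomes 3-carboxyphenyl: carboxy in place of hydrogen on an aromatic carbon.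

Within the data shown here, only one measured step bears on this change. It also replaces a hydrogen on an aromatic carbon, here with hydroxy, and it is modest: a 2.9-fold lower number from compound 1 to compound 2 (0.46 log units; beyond the scatter). Carboxy is a different group from hydroxy, so this single step offers a hint and not a rule. In this assay, a small move toward a lower number is therefore expected, possibly none beyond the scatter. The estimate means an expected 1.7-fold lower number from compound 1 to compound 3 (0.22 log units; within the scatter). For compound 3 the estimated value is 1200 nM, with an expected range from 300 nM to 4500 nM.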

Compound 3, half-maximal inhibitory concentration: 500 nM
Compound 3: the middle estimate sits 2.4-fold (0.38 log units) above what was measured, within the range that was stated.
By their numbers in this assay, from the lowest: compounds 3 and 2 (each within the scatter of the next); then compound 1.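

In this assay, carboxy in place of hydrogen on this aromatic carbon, meta to a large group, gives a step beyond the scatter (a 4.0-fold lower number from compound 1 to compound 3 (0.60 log units; beyond the scatter)), so a second group at this place moves the number in the same direction as hydroxy did. Swapping one of these groups for the other makes no difference that can be read (a 1.4-fold lower number from compound 2 to compound 3 (0.15 log units; within the scatter)): that step lies within the scatter, so this assay does not separate compound 2 from compound 3, even though carboxy has more heavy atoms than hydroxy. Why either group lowers the number compared with hydrogen cannot be said, as no measurement here addresses the cause.

Going by these compounds, two groups at a single place are too few to show a trend, so it remains open whether an amine, a methyl group or a longer chain ending in a carboxylic acid would lower the number as well. Also open, on these data alone, is whether carboxy would give a similar step on another carbon of the same ring, or on a compound with a different core.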